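The compounds below may be only part of what the source reports. "The series", "measured", "known", "first", "only" and "open" are said of these compounds alone.

Measured compounds:
Compound 1, `Cc1ccc(C(=O)NNC(=S)Nc2csc(-c3ccc(C)cc3)c2)cc1`: in a functional assay on U-373MG ATCC cells (Homo sapiens) for inhibition, read by colorimetric assay and MTT assay, with a stated time of 72 h (on this read-out lower numbers stand for stronger inhibition and higher numbers for weaker inhibition), compound 1 gives 38000 nM.
Compound 2, `COc1cc(C(=O)NNC(=S)Nc2csc(-c3ccccc3)c2)cc(OC)c1OC`: in this assay compound 2 gives 44000 nM.

Among the measured compounds shown here, compound 2 holds the highest of the two numbers so far, but its nearest neighbour, compound 1, sits within the usual scatter of it, so the two values show no order between them. For the measured compounds named here, the two compounds differ in more than one place, and no single-point step between measured compounds is available.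

Compound 3, `COc1cc(C(=O)NNC(=S)Nc2csc(-c3ccc(C)cc3)c2)cc(OC)c1OC`, is the next member. It differs from compound 2 by methyl in place of hydrogen on an aromatic carbon. Going by the values given here, no measured pair isolates this change, so nothing in the data points to a direction. The expected step from compound 2 to compound 3 is a 1.1-fold lower number from compound 2 to compound 3 (0.04 log units; within the scatter), that is, none beyond the scatter. Compound 3 is therefore expected near 40000 nM in this assay, with a range from 18000 nM to 90000 nM.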

Compound 3, half-maximal inhibitory concentration: 47000 nM
Estimate against measurement, compound 3: 1.2-fold (0.07 log units) below; the measured number falls inside the stated range.
By their numbers in this assay, from the lowest: compounds 1, 2 and 3 (each within the scatter of the next).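

Among the compounds shown here, compound 2 and compound 3 form the first pair that differs in one place, and in this assay the change from phenyl to 4-methylphenyl, para to a large group, gives no readable shift (a 1.1-fold higher number from compound 2 to compound 3 (0.03 log units; within the scatter)). This position therefore accepts a methyl in place of hydrogen without a step beyond the scatter, though this is shown for one background only. Nothing at hand offers an explanation for this flat step.

Still open, from the compounds shown here alone, is whether this position stays as flat with a group other than methyl, such as an amine, a carboxylic acid or a longer alkyl chain. Also open, going by these compounds, is whether the same methyl change reads the same when the rest of the molecule carries other substituents.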